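The source may report more compounds than this note shows. Statements on the series, on what has been measured and on what is new or still open speak of the compounds shown alone.

Measured compounds:
Compound 1, `C=CC(=O)Nc1cccc(NC(=O)CSc2nc(Nc3ccccc3)c3ccccc3n2)c1`, gives 8740 nM in a functional assay on PC-3 cells (Homo sapiens) for inhibition, read by MTT assay, with a stated time of 72 h; on this read-out higher numbers stand for weaker inhibition and lower numbers for stronger inhibition.
Compound 2, `C=CC(=O)Nc1cccc(NC(=O)CSc2nc(Nc3ccccc3F)c3ccccc3n2)c1`, gives 9340 nM in this assay.
Compound 3, `C=CC(=O)Nc1cccc(NC(=O)CSc2nc(Nc3ccccc3C)c3ccccc3n2)c1`, gives 23200 nM in this assay.

Compound 3 holds the highest number of the three; its nearest neighbour is compound 2, with a 2.5-fold higher number from compound 2 to compound 3 (0.40 log units; beyond the scatter), and compound 1 lies furthest, with a 2.7-fold higher number from compound 1 to compound 3 (0.42 log units; beyond the scatter). Compound 4, `C=CC(=O)Nc1cccc(NC(=O)CSc2nc(Nc3cccc(F)c3)c3ccccc3n2)c1`, has not been measured. Its change from compound 3 is 3-fluorophenyl in place of 2-methylphenyl on a nitrogen on an aromatic ring. Within the data shown here, two measured steps bear on it. The step from compound 1 to compound 2, a 1.1-fold higher number from compound 1 to compound 2 (0.03 log units; within the scatter), shows that fluoro on an aromatic carbon in place of hydrogen left the number where it was. The step of a 2.5-fold higher number from compound 2 to compound 3 (0.40 log units; beyond the scatter) and the step of a 2.7-fold higher number from compound 1 to compound 3 (0.42 log units; beyond the scatter) show that the methyl of compound 3 is where the higher number arose. Since compound 4 carries no methyl and a fluoro instead, the number is expected to fall back toward that of compound 1 and compound 2, a step of a 2.3-fold lower number from compound 3 to compound 4 (0.37 log units; beyond the scatter). Compound 4 is therefore estimated at 10000 nM, within a range of 5000 nM to 25000 nM.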

Compound 4, half-maximal inhibitory concentration: 5370 nM
Estimate against measurement, compound 4: 1.9-fold (0.27 log units) above; the measured number falls inside the stated range.
By their numbers in this assay, from the lowest: compounds 4, 1 and 2 (each within the scatter of the next); then compound 3.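

In this assay, 3-fluorophenyl in place of 2-methylphenyl on the nitrogen gives a 4.3-fold lower number from compound 3 to compound 4 (0.64 log units; beyond the scatter), so the higher number of compound 3 does not extend to this second fluorinated ring. Moving the fluoro gives a 1.7-fold lower number from compound 2 to compound 4 (0.24 log units; within the scatter), and adding it to the plain phenyl gives a 1.6-fold lower number from compound 1 to compound 4 (0.21 log units; within the scatter), so the phenyl, 2-fluorophenyl and 3-fluorophenyl groups cannot be told apart here, and among the four compounds only the 2-methylphenyl group stands apart. Nothing available accounts for this difference.

From the compounds shown here alone, it remains open whether a methyl elsewhere on this phenyl ring would also raise the number, or whether that result belongs to the 2-methylphenyl group alone. Going by these compounds, how a methoxy group, an amine or a carboxylic acid on this ring would read in this assay is also open.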